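Replacing an Amino Group with a Second Selenium Chain

The compounds below may be only part of what the source reports. "The series", "measured", "known", "first", "only" and "open" are said of these compounds alone.

Compound 1 `CCCCC[Se]c1nc(N)c2ccccc2n1` was tested in an ADME assay on 184B5 cells (Homo sapiens) for cytotoxicity, read by MTT assay, with a stated time of 72 h (on this read-out higher numbers stand for weaker inhibition of growth and lower numbers for stronger inhibition of growth), where compound 1 gives 43600 nM. Among the three measured compounds this is the second highest number: compound 2 `C[Se]c1nc(N)c2ccccc2n1` gives 59000 nM and compound 3 `Nc1nc([SeH])nc2ncccc12` gives 31100 nM, and both of these lie within the scatter of compound 1. Compound 4 `CCCCC[Se]c1nc([Se]CCCCC)c2ccccc2n1` differs from compound 1 by a group of 6 heavy atoms (5 carbon, 1 selenium; no ring) in place of one nitrogen atom, on an aromatic carbon. Among the measured compounds shown here, the only measured step touching a chain on selenium is a 1.4-fold higher number from compound 1 to compound 2 (0.13 log units; within the scatter), which lies within the scatter. For the measured compounds named here, no measured step removes the amino group, so the effect of that exchange is unknown. A shift no larger than the scatter is therefore expected, giving a 1.1-fold lower number from compound 1 to compound 4 (0.04 log units; within the scatter). Compound 4 is estimated at 40000 nM, within 15000 nM to 110000 nM.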

Compound 4, concentration for total growth inhibition: > 100000 nM
Compound 4: no number, only a limit (the forecaster's own chance of this, stated with the estimate: 10%); middle value at least 2.5-fold (0.39 log units) away from the limit.
By their numbers in this assay, from the lowest: compounds 3, 1 and 2 (each within the scatter of the next). At a limit, above all of these: compound 4.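

In this assay, putting a second pentyl-selenium chain in place of the amino group gives an at least 2.2-fold higher number from compound 1 to compound 4 (0.36 log units; beyond the scatter) and so weaker inhibition of growth. Among the compounds shown here, until now the only measured step, a change to the chain on selenium, stayed within the scatter, so this aromatic carbon is the first place where a change clearly moves the read-out. For compound 4 the value is a limit and not a number: the limit of > 100000 nM in this assay, at which 1 of the 4 values shown sits.

On these data alone, it remains open how far the number of compound 4 lies beyond that limit. Also open, as far as these compounds go, is whether a methylamino group or a shorter methyl-selenium chain at this carbon would keep the number near that of compound 1.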